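From thiophen-3-yl to pyridin-3-yl: a ring swap

A few compounds are considered here, and "the series" means these few. Any claim that something is new, unique, unknown or untested is made for them only; others in the source may bear on it.

Measured in a functional assay on U-937 cells (Homo sapiens), read by cAMP accumulation; on this read-out lower numbers stand for an effect already at smaller amounts and higher numbers for an effect only at larger amounts of compound:
- compound 1 `CCc1nn(C2CCCC2)c2c1CCN(c1ccccc1)C2=O`: 70 nM
- compound 2 `CCc1nn(C2CCCC2)c2c1CCN(c1ccccc1C)C2=O`: 330 nM
- compound 3 `CCc1nn(C2CCCC2)c2c1CCN(c1ccsc1)C2=O`: 36 nM

Compound 3 sits together with compound 1 at the low end of these three numbers, while compound 2 stands clearly apart: a 9.2-fold lower number from compound 2 to compound 3 (0.96 log units; beyond the scatter).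

The next compound to be measured is compound 4 `CCc1nn(C2CCCC2)c2c1CCN(c1cccnc1)C2=O`. It keeps the shared core and carries pyridin-3-yl in place of thiophen-3-yl on an amide-type nitrogen in a ring.

Among the measured compounds shown here, the closest precedent is another exchange of one aromatic ring for another at the same place, and it moved the number very little: a 1.9-fold lower number from compound 1 to compound 3 (0.29 log units; within the scatter). The larger step, a 4.7-fold higher number from compound 1 to compound 2 (0.67 log units; beyond the scatter), came from adding a methyl, and compound 4 has no such methyl, so that step bears on it only weakly. For the measured compounds named here, no measured compound carries a ring containing nitrogen at this place, which leaves real uncertainty.

A large shift in this assay is therefore not expected, and any change should stay within the scatter. The expected step is a 1.7-fold higher number from compound 3 to compound 4 (0.22 log units; within the scatter). For compound 4 the estimated value is 60 nM, with an expected range of 20 nM to 180 nM.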

Compound 4, half-maximal effective concentration: 17 nM
Estimate against measurement, compound 4: 3.5-fold (0.55 log units) above; the measured number lies below the stated range.
By their numbers in this assay, from the lowest: compound 4; then compounds 3 and 1 (each within the scatter of the next); then compound 2.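

In this assay compound 4 shows that a ring containing nitrogen is accepted on the amide-type nitrogen, and that the choice of aromatic ring here can matter more than the phenyl and thiophen-3-yl pair suggested. Those two rings stayed within the scatter of each other, whereas pyridin-3-yl separates from both (a 2.1-fold lower number from compound 3 to compound 4 (0.33 log units; beyond the scatter)) and (a 4.1-fold lower number from compound 1 to compound 4 (0.61 log units; beyond the scatter)). Compound 4 now stands alone at the low end, the most potent of the four, and its widest gap is to the methyl-bearing ring (a 19-fold lower number from compound 2 to compound 4 (1.29 log units; beyond the scatter)), but no measurement shown explains why pyridin-3-yl gives the lowest number.

Among the compounds shown here, with only one nitrogen-containing ring in the set, it remains open whether pyridin-2-yl, pyridin-4-yl or pyrimidin-5-yl would give similar numbers, or whether the result is specific to pyridin-3-yl. On these data alone, it is also open whether a methyl on the pyridin-3-yl ring would raise the number as it did on the phenyl ring, and whether the gain holds when the ethyl or cyclopentyl group of the shared core is replaced.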